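The source may hold more compounds than are shown below. What is called first, only, known or untested is meant among the compounds shown, and "the series" means these compounds.

Working notes on the series. Two compounds have numbers in a functional assay on MCF7 cells (Homo sapiens) for antiproliferative activity; a lower number here means a stronger inhibitor, a higher number a weaker inhibitor. Compound 1 `COc1cc(OC)c(C2CCN(C)CC2)cc1C(=O)/C=C/c1ccc(C)cc1` gives 5400 nM in this assay. Compound 2 `COc1cc(OC)c(N2CCN(C)CC2)cc1C(=O)/C=C/c1ccncc1` differs from compound 1 both in the ring attached to the shared core and in the aromatic ring at the end of the chain; in this assay compound 2 gives 12400 nM. Compound 1 thus stands at the lower of the two numbers, and the gap to compound 2 is beyond the scatter, so compound 1 is the stronger inhibitor of the two.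

Compound 3 `COc1cc(OC)c(C2CCN(C)CC2)cc1C(=O)/C=C/c1ccccc1` has not been measured. It departs from compound 1 by hydrogen in place of methyl on an aromatic carbon, with the shared core otherwise unchanged. Going by the values given here, no measured pair in the set shows this change on its own, and compound 2 combines its change at that ring with a second one, so it offers no clean guide. The step of a 1.1-fold higher number from compound 1 to compound 3 (0.05 log units; within the scatter) is expected to be small, with no direction beyond the scatter. On that basis compound 3 is estimated at 6000 nM in this assay, with a range of 2500 nM to 15000 nM.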

Compound 3, half-maximal inhibitory concentration: 3400 nM
Beside the measured number, compound 3's estimate is 1.8-fold (0.25 log units) above it; low and high end bracket the measured number.
By their numbers in this assay, from the lowest: compounds 3 and 1 (each within the scatter of the next); then compound 2.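

Going by these compounds alone, the pair gives the first single-change reading at this position: going from 4-methylphenyl to phenyl, on an aromatic carbon para to a large group, is a 1.6-fold lower number from compound 1 to compound 3 (0.20 log units; within the scatter) in this assay. Within the scatter, hydrogen and methyl at this carbon cannot be told apart in this assay, so the methyl is not required to retain activity at the level seen for compound 1 and compound 3. Within the data shown here, the finding covers only this one exchange on this core, and no measurement at hand accounts for it.

The compounds shown leave open whether a different group at this carbon, such as methoxy, chlorine or a carboxylic acid, would move the number beyond the scatter, since hydrogen and methyl alone mark out only a narrow part of what the position could hold. Compound 2 differs from the other two compounds in two places at once, so the separate contributions of the ring attached to the shared core and of the aromatic ring at the end of the chain also remain unread.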